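The source may hold more compounds than are shown below. What is called first, only, known or untested is meant among the compounds shown, and "the series" means these compounds.

Compound 3 `COc1ccc(NC(=O)NCCCOc2cccc(CN3CCCCC3)c2)c(OC)c1` gives 2240 nM in an assay on isolated protein for inhibition of histamine H2 receptor (Cavia porcellus); on this read-out higher numbers stand for weaker binding and lower numbers for tighter binding. Compound 1 `COc1ccc(N/C(S)=N/CCCOc2cccc(CN3CCCCC3)c2)cc1` gives 4370 nM, and the two values lie close together. Compound 2 `O=C(NCCCOc1cccc(CN2CCCCC2)c1)NCc1ccccc1` gives 347 nM, and the measured step of a 6.5-fold higher number from compound 2 to compound 3 (0.81 log units; beyond the scatter) shows that an aromatic group on the urea nitrogen in place of benzyl weakened binding. Compound 4 `CCC(C)NC(=O)NCCCOc1cccc(CN2CCCCC2)c1` differs from compound 3 by sec-butyl in place of 2,4-dimethoxyphenyl on an amide-type nitrogen. For the measured compounds named here, the only step that bears on this change is the one from compound 2 to compound 3, and it points in the opposite direction: removing the aromatic group and moving to a small chain is therefore expected to tighten binding, roughly back toward the level of compound 2. Compound 4 is estimated at 500 nM, within 150 nM to 2000 nM, an expected step of a 4.5-fold lower number from compound 3 to compound 4 (0.65 log units; beyond the scatter).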

Compound 4, dissociation constant: 95.5 nM
Compound 4: middle estimate off by 5.2-fold (0.72 log units), on the high side; the whole stated range lies above it.
By their numbers in this assay, from the lowest: compound 4; then compound 2; then compounds 3 and 1 (each within the scatter of the next).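

Sec-butyl on the amide-type nitrogen tightens binding compared with 2,4-dimethoxyphenyl (a 23-fold lower number from compound 3 to compound 4 (1.37 log units; beyond the scatter)) and also compared with benzyl (a 3.6-fold lower number from compound 2 to compound 4 (0.56 log units; beyond the scatter)). Every earlier compound carried an aromatic ring on this side of the molecule, so only now is it clear that tight binding does not need one here. Nothing measured accounts for these steps.

Whether the branching of sec-butyl matters remains open, since a straight butyl chain is not among these compounds. A cyclohexyl ring or a smaller methyl group at this position would also be untested here.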